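The compounds below may be only part of what the source reports. "The series", "measured", "known", "first", "only" and "open" are said of these compounds alone.

In a functional assay on L02 cells (Homo sapiens) for inhibition, read by Griess assay, with stated times of 1 h and 24 h (a lower number here means a stronger inhibitor, a higher number a weaker inhibitor), compound 3 (`C(=C/c1ccco1)\c1nc(NC2CC2)c2sccc2n1`) gives only a limit (> 1000000 nM). Compound 2 (`CNc1nc(/C=C/c2ccco2)nc2ccsc12`) gives 811000 nM in this assay and carries methyl where compound 3 carries cyclopropyl on a nitrogen on an aromatic ring. That single measured step (an at least 1.2-fold higher number from compound 2 to compound 3 (0.09 log units; that floor lies within the scatter)) stays within the scatter, so it gives no sign that a change of this small amine matters.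

The next change is larger. In compound 4 (`CN1CCN(c2nc(/C=C/c3ccco3)nc3ccsc23)CC1`), 4-methylpiperazin-1-yl stands in place of cyclopropylamino on an aromatic carbon, next to the ring nitrogen (4-methylpiperazin-1-yl in place of cyclopropylamino on an aromatic carbon). Within the data shown here, no measured step isolates this exchange. The nearest evidence is compound 1 (`CN1CCN(c2nc(/C=C/c3ccccc3)nc3ccsc23)CC1`), which already carries 4-methylpiperazin-1-yl but differs from compound 4 elsewhere, as its structure shows. In this assay compound 1 gives 198000 nM, a lower number than the value of compound 2 (811000 nM).

On the strength of compound 1 at 198000 nM, a move toward a lower number, and so a stronger inhibitor, is expected, though this rests on a single comparison. The expected change is an at least 2.8-fold lower number from compound 3 to compound 4 (0.45 log units; beyond the scatter) and remains an estimate resting on a limit. Compound 4 is estimated at 350000 nM in this assay, with an expected range from 120000 nM to 1000000 nM.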

Compound 4, half-maximal inhibitory concentration: > 1000000 nM
Compound 4: a limit, no number (the forecaster's own chance of this, stated with the estimate: 25%); middle value at least 2.8-fold (0.45 log units) away from the limit.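

With furan-2-yl on the chain, 4-methylpiperazin-1-yl on this aromatic carbon, next to the ring nitrogen, shows no gain over methylamino in this assay: the result is an at least 1.2-fold higher number from compound 2 to compound 4 (0.09 log units; that floor lies within the scatter), and the step from compound 3 to compound 4 cannot be read, as both ends are limits. The clearer finding concerns the other end of the molecule: with 4-methylpiperazin-1-yl held fixed, furan-2-yl in place of phenyl gives an at least 5.0-fold higher number from compound 1 to compound 4 (0.70 log units; beyond the scatter), so the lower number of compound 1 does not carry over to its furan-2-yl counterpart. The furan-2-yl compounds therefore leave little room for ranking groups at this position: the limit of > 1000000 nM in this assay, at which 2 of the 4 values shown sit.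

Going by these compounds, it remains open how methylamino or cyclopropylamino would read with phenyl on the chain, and so whether the group on this aromatic carbon matters at all once values stand clear of the limit. Also open, on these data alone, is whether a longer-chain amine at this position, or a carboxylic acid on the phenyl ring, would move the number in either direction.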